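Replacing the sulfonyl linker with a carbamoyl linker

The source may report more compounds than this note shows. Statements on the series, on what has been measured and on what is new or still open speak of the compounds shown alone.

Measured compounds:
compound 1 `Cc1ccc(S(=O)(=O)Nc2cccc(-c3nc(-c4ccc(NC(=O)c5cccnc5)cc4Cl)no3)c2)cc1`: > 10000 nM
compound 2 `CCNC(=O)Nc1ccc(S(=O)(=O)Nc2cccc(-c3nc(-c4ccc(NC(=O)c5cccnc5)cc4Cl)no3)c2)cc1`: 3100 nM
compound 3 `O=C(Nc1ccc(S(=O)(=O)Nc2cccc(-c3nc(-c4ccc(NC(=O)c5cccnc5)cc4Cl)no3)c2)cc1)NC1CCCC1`: > 10000 nM

In a functional assay on MDA-MB-231 cells (Homo sapiens) for antiproliferative activity, read by MTT assay, with a stated time of 72 h (on this read-out lower numbers stand for stronger inhibition and higher numbers for weaker inhibition), compound 1 gives > 10000 nM, which is a limit of the assay and not a number. Compound 1 thus stands at the limit of > 10000 nM in this assay, at which 2 of the 3 values shown sit. Within the data shown here, compound 2 gives 3100 nM, the only number in the set. Compound 3 gives > 10000 nM, again a limit. Among the measured compounds shown here, the one readable step is an at least 3.2-fold lower number from compound 1 to compound 2 (0.50 log units; beyond the scatter); the step that the two limits leave unreadable from compound 1 to compound 3; and an at least 3.2-fold higher number from compound 2 to compound 3 (0.50 log units; beyond the scatter).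

Compound 4 `COc1cccc(NC(=O)Nc2cccc(-c3nc(-c4ccc(NC(=O)c5cccnc5)cc4Cl)no3)c2)c1` is not yet measured. It differs from compound 1 by (3-methoxyphenyl)carbamoyl in place of (4-methylphenyl)sulfonyl on a nitrogen on an aromatic ring. For the measured compounds named here, all three measured steps vary only the substituent on the outer aromatic ring and keep the sulfonyl linkage, so none bears directly on this change; the measured series gives no precedent for the carbamoyl link or for the 3-methoxyphenyl group. From the compounds shown here alone, because compound 1 stands only at the limit of > 10000 nM in this assay, at which 2 of the 3 values shown sit, the starting point itself is unknown, and any step can be read only as an expectation against that limit. Compound 4 is expected at 6000 nM, a range from 1500 nM to 20000 nM. The estimated step is an at least 1.6-fold lower number from compound 1 to compound 4 (0.22 log units; that floor lies within the scatter), an expectation that carries little weight given the limit at which compound 1 sits.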

Compound 4, half-maximal inhibitory concentration: 6700 nM
Compound 4: middle estimate off by 1.1-fold (0.05 log units), on the low side; the range from low to high includes it.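

On the nitrogen on an aromatic ring, (3-methoxyphenyl)carbamoyl in place of (4-methylphenyl)sulfonyl leaves a measurable number in this assay: compound 4 gives 6700 nM, so within the compounds shown a number at this position does not depend on the sulfonyl linkage. The change reads as an at least 1.4-fold lower number from compound 1 to compound 4 (0.17 log units; that floor lies within the scatter), so no gain beyond the scatter can be claimed. The value of compound 1 is a limit, which gives the step a floor but no measured size: the limit of > 10000 nM in this assay, at which 2 of the 4 values shown sit.

The linker and the outer ring substitution change together in this step, so the share of each stays unresolved. Also open, from the compounds shown here alone, is how the carbamoyl linkage behaves with a different outer group, such as a morpholine ring or a carboxylic acid on the outer ring.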